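The source may hold more compounds than are shown below. What is called first, only, known or untested is meant among the compounds shown, and "the series" means these compounds.

Compound 1 `C/N=C(/S)C1=CC(C)(C)Oc2ccc(S(C)(=O)=O)cc21` — 457 nM
Compound 2 `C/N=C(/S)C1=CC(C)(C)Oc2ccc(C(F)(F)F)cc21` — 2.04 nM
Compound 3 `C/N=C(/S)C1=CC(C)(C)Oc2ccc(OC(F)(F)F)cc21` — 4.07 nM

Of the compounds shown here, three sharing one core have been measured in a functional assay (aorta) with Rattus norvegicus as the target; on this read-out higher numbers stand for an effect only at larger amounts of compound and lower numbers for an effect already at smaller amounts. Compound 3 sits close to compound 2: the step of a 2.0-fold higher number from compound 2 to compound 3 (0.30 log units; within the scatter) is inside the usual scatter, so the two cannot be told apart. Against compound 1, however, compound 3 stands far off, as a 110-fold lower number from compound 1 to compound 3 (2.05 log units; beyond the scatter) shows, and compound 2 is likewise far from compound 1, as a 220-fold lower number from compound 1 to compound 2 (2.35 log units; beyond the scatter) shows. Both large steps replace methylsulfonyl with a fluorinated group on the aromatic carbon.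

Compound 4 `C/N=C(/S)C1=CC(C)(C)Oc2ccccc21` carries the change (hydrogen in place of trifluoromethoxy on an aromatic carbon). Within the data shown here, no measured step removes a substituent from this position altogether, so the three measured steps bear on it only indirectly: they show that the group on that aromatic carbon can shift the number by a very large margin, while the two fluorinated groups give numbers in the same band. Compound 4 is therefore expected to move away from compound 3 in the direction of compound 1, as an estimated step of a 20-fold higher number from compound 3 to compound 4 (1.29 log units; beyond the scatter), giving an estimated value of 80 nM with a range from 10 nM to 600 nM.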

Compound 4, half-maximal effective concentration: 4270 nM
Beside the measured number, compound 4's estimate is 53-fold (1.73 log units) below it; the whole stated range lies below it.
By their numbers in this assay, from the lowest: compounds 2 and 3 (each within the scatter of the next); then compound 1; then compound 4.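

In this assay, among these compounds, hydrogen in place of a fluorinated group proves a very large change at this position: a 1000-fold higher number from compound 3 to compound 4 (3.02 log units; beyond the scatter) and a 2100-fold higher number from compound 2 to compound 4 (3.32 log units; beyond the scatter) are both far beyond anything the earlier steps showed. Even the replacement of methylsulfonyl, the group with the highest number among the three substituted compounds, gives a 9.3-fold higher number from compound 1 to compound 4 (0.97 log units; beyond the scatter) and remains beyond the scatter, so all three substituents give lower numbers than the unsubstituted aromatic carbon, with no compound shown going against this. No measured evidence accompanies these compounds to explain the pattern.

The compounds shown leave open where an amine, a carboxylic acid, a methoxy group or a chlorine atom on this aromatic carbon would fall. They also leave open whether a longer fluorinated chain would stay in the band of compound 2 and compound 3.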